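A Chloropyrazole in Place of a Methylpyrazole

The compounds below may be only part of what the source reports. "The series", "measured", "known", "first", "only" and "open" are said of these compounds alone.

Compound 3 `CCOc1ncc(-c2nc(C(F)(F)F)sc2N2CCN(C(=O)Cn3nccc3C)[C@H](C)C2)cn1` stands second highest among the three numbers: in an assay on blood for inhibition of C-X-C chemokine receptor type 3 (Homo sapiens), with a stated time of 30 min (on this read-out lower numbers stand for stronger inhibition and higher numbers for weaker inhibition), compound 3 gives 289 nM. Compound 1 `O=C(Cn1cnc2cccnc21)N1CCN(c2scnc2-c2nc3ccccc3[nH]2)CC1` gives 1440 nM in this assay, and compound 2 `CCOc1ncc(-c2nc(C(F)(F)F)sc2N2CCN(C(=O)Cn3ccc4cccnc43)[C@H](C)C2)cn1` gives 47 nM. Going by the values given here, the one measured step that reaches compound 3 is a 6.1-fold higher number from compound 2 to compound 3 (0.79 log units; beyond the scatter), an exchange of the whole group on the chain carbon. Compound 4 `CCOc1ncc(-c2nc(C(F)(F)F)sc2N2CCN(C(=O)Cn3cc(Cl)cn3)[C@H](C)C2)cn1` differs from compound 3 by 4-chloro-1H-pyrazol-1-yl in place of 5-methyl-1H-pyrazol-1-yl on a saturated chain carbon bound to a carbonyl carbon. Among the compounds with values here, no measured step exchanges one pyrazole for another, so the step from compound 2 bears only loosely on this change and gives no direction. The step is therefore expected to stay within the usual scatter: a 1.1-fold lower number from compound 3 to compound 4 (0.05 log units; within the scatter). For compound 4 the estimate in this assay is 260 nM, with a range from 90 nM to 800 nM.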

Compound 4, half-maximal inhibitory concentration: 245 nM
The estimate for compound 4 lay 1.1-fold (0.03 log units) above the measured number, within the range that was stated.
By their numbers in this assay, from the lowest: compound 2; then compounds 4 and 3 (each within the scatter of the next); then compound 1.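

In this assay the step to 4-chloro-1H-pyrazol-1-yl from 5-methyl-1H-pyrazol-1-yl is a 1.2-fold lower number from compound 3 to compound 4 (0.07 log units; within the scatter) and stays inside the scatter, so at this place, on a saturated chain carbon bound to a carbonyl carbon, these two pyrazoles cannot be told apart. The step from the two-ring group to the chloropyrazole, a 5.2-fold higher number from compound 2 to compound 4 (0.72 log units; beyond the scatter) and beyond the scatter, shows that a second pyrazole also stays well short of that group. Nothing measured here gives a cause for either step.

The compounds shown leave open whether an amine or a carboxylic acid on the pyrazole would move the number, and whether chlorine placed elsewhere on that ring would read the same.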